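The source may hold more compounds than are shown below. What is called first, only, known or untested is meant among the compounds shown, and "the series" means these compounds.

Compound 1 `O=C(Nc1ccc(C(F)(F)F)cc1)c1cc(Cl)c(-c2ccccc2)cc1O`: 490 nM
Compound 2 `O=C(Nc1ccc(C(F)(F)F)cc1)c1cc(Br)ccc1O`: 580 nM

In a functional assay on HL-60 cells (Homo sapiens) for cytotoxicity, read by luminescence and CellTiter-Glo, with a stated time of 3 days (a higher number here means a weaker inhibitor, a lower number a stronger inhibitor), the two measured compounds lie within the usual scatter of each other, so compound 2 cannot be separated from compound 1. Compound 3 (`O=C(Nc1ccc(C(F)(F)F)cc1)c1cc(Br)c(-c2ccccc2)cc1O`) differs from compound 2 by one change, (phenyl in place of hydrogen on an aromatic carbon), on an aromatic carbon ortho to a bromo group. Among the measured compounds shown here, no measured step shows the effect of this change. For the measured compounds named here, the only other guide is compound 1 at 490 nM, so no step beyond the scatter is expected in this assay. The expected change is a 1.4-fold lower number from compound 2 to compound 3 (0.14 log units; within the scatter). Compound 3 is estimated at 420 nM, with an expected range of 160 nM to 1100 nM.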

Compound 3, half-maximal inhibitory concentration: 540 nM
Estimate against measurement, compound 3: 1.3-fold (0.11 log units) below; the measured number falls inside the stated range.
By their numbers in this assay, from the lowest: compounds 1, 3 and 2 (each within the scatter of the next).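

In this assay, phenyl in place of hydrogen on the aromatic carbon ortho to a bromo group gives a 1.1-fold lower number from compound 2 to compound 3 (0.03 log units; within the scatter), so this position carries the added ring with no step beyond the scatter. With the phenyl present, bromo in place of chloro gives a 1.1-fold higher number from compound 1 to compound 3 (0.04 log units; within the scatter), and this halogen change also cannot be separated from the scatter. Nothing available explains these results.

Going by these compounds, whether an amine or a carboxylic acid on this same carbon would give a step beyond the scatter remains open. The compounds shown also leave open how a methoxy group in place of the bromo group would read.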